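Shortening the chain of compound 2

The source may hold more compounds than are shown below. What is called first, only, known or untested is meant among the compounds shown, and "the series" means these compounds.

Measured in a functional assay on L1210 cells (Mus musculus) for antiproliferative activity, read by MTT assay, with a stated time of 2 days; a higher number here means a weaker inhibitor, a lower number a stronger inhibitor:

compound 1 `Cc1ccc(C#Cc2cn(C/C=C\CN3C(=O)c4ccccc4C3=O)c(=O)[nH]c2=O)cc1` gives 245000 nM
compound 2 `CCCCCCCCC#Cc1cn(C/C=C/CN2C(=O)c3ccccc3C2=O)c(=O)[nH]c1=O` gives > 250000 nM
compound 3 `O=C1c2ccccc2C(=O)N1C/C=C\Cn1cc(C#CCCc2ccccc2)c(=O)[nH]c1=O` gives 143000 nM

Compound 2 gives the reading > 250000 nM, which is a limit of the assay and not a number, as the limit of > 250000 nM in this assay, at which 1 of the 3 values shown sits, records. Compound 4 `CCCCC#Cc1cn(C/C=C/CN2C(=O)c3ccccc3C2=O)c(=O)[nH]c1=O` differs from it as follows: hydrogen in place of butyl on a saturated chain carbon, four bonds along the chain from a triple-bonded carbon, in words hydrogen in place of butyl on a saturated chain carbon, four bonds along the chain from a triple-bonded carbon. Among the measured compounds shown here, the one measured step that bears on this, a 1.7-fold lower number from compound 1 to compound 3 (0.23 log units; within the scatter), also changes what the triple-bonded carbon carries. It therefore gives no ground to expect a change beyond the scatter in this assay. The expected step is an at least 1.3-fold lower number from compound 2 to compound 4 (0.11 log units; that floor lies within the scatter). For compound 4 the estimated value is 190000 nM, with an expected range from 90000 nM to 350000 nM.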

Compound 4, half-maximal inhibitory concentration: 236000 nM
Beside the measured number, compound 4's estimate is 1.2-fold (0.09 log units) below it; the measured number falls inside the stated range.
By their numbers in this assay, from the lowest: compounds 3, 4 and 1 (each within the scatter of the next). At a limit, above all of these: compound 2.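

In this assay, the change at this position comes to an at least 1.0-fold lower number from compound 2 to compound 4 (0.02 log units; that floor lies within the scatter). For compound 2 the reading > 250000 nM is a limit of the assay and not a number. Hydrogen in place of butyl on this saturated chain carbon thus gives the first step that touches the chain alone, and it shows no change beyond the scatter.

The compounds shown leave open whether an amine or a carboxylic acid at this place on the chain would move the number beyond the scatter.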